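The source may hold more compounds than are shown below. What is called first, only, known or untested is meant among the compounds shown, and "the series" means these compounds.

In an assay on cells for inhibition of interleukin-5 receptor subunit alpha (Mus musculus), read by WST assay, with a stated time of 48 h, tested at 30 uM, in the presence of a further agent that is not named here (a lower number here means less inhibition, a higher number more inhibition at the concentration tested (going by the name of the read-out)), compound 1 `CCC(CO)NCc1nc2c(OCC3CCCCC3)cccc2[nH]1` gives 94.3%, compound 2 `c1ccc(CNCc2nc3c(OCC4CCCCC4)cccc3[nH]2)cc1` gives 49.3%, and compound 3 `c1ccc(NCc2nc3c(OCC4CCCCC4)cccc3[nH]2)cc1` gives 25%, the lowest of the three numbers. The steps of a number 45 percentage points lower from compound 1 to compound 2 (beyond the scatter) and a number 69.3 percentage points lower from compound 1 to compound 3 (beyond the scatter) are large, and the step of a number 24.3 percentage points lower from compound 2 to compound 3 (beyond the scatter) is modest, so within these three compounds an aryl group on the amine nitrogen goes with less inhibition. Compound 4 `COc1ccc(NCc2nc3c(OCC4CCCCC4)cccc3[nH]2)cc1` differs from compound 3 in one place: methoxy in place of hydrogen on an aromatic carbon. Among the compounds with values here, no measured step alters the phenyl ring itself, so the measured steps bear on compound 4 only by fixing its starting point near the bottom of the series. The expected step of a number 3 percentage points higher from compound 3 to compound 4 (within the scatter) is therefore small, with no direction claimed beyond the scatter. Compound 4 is estimated at 28% in this assay, with a range from 10% to 50%.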

Compound 4, a percentage reported as inhibition, at one concentration (the size of the read-out at that concentration, not a potency): 20.3%
Compound 4: the middle estimate sits 7.7 percentage points above what was measured; the range from low to high includes it.
By their numbers in this assay, from the lowest: compounds 4 and 3 (each within the scatter of the next); then compound 2; then compound 1.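

Methoxy in place of hydrogen on the phenyl ring, para to a large group, gives a number 4.7 percentage points lower from compound 3 to compound 4 (within the scatter), so this first change to the ring itself does not move the number beyond the scatter. The gaps to the non-aryl amine substituents remain: 4-methoxyphenyl gives a number 29 percentage points lower from compound 2 to compound 4 (beyond the scatter) and a number 74 percentage points lower from compound 1 to compound 4 (beyond the scatter). No evidence here bears on the reason for these results.

Still open, as far as these compounds go, is whether a carboxylic acid or an amine on the same ring carbon would shift the number. Also open, from the compounds shown here alone, is how a longer chain ending in hydroxyl on the amine nitrogen would compare with compound 1.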